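Hydroxy to sulfanyl on the fused core: compound 4

The compounds below may be only part of what the source reports. "The series", "measured", "known", "first", "only" and "open" are said of these compounds alone.

The series shares the core of compound 1 `Cc1ncn2c(O)nncc12`. In a functional assay for inhibition, with Homo sapiens as the target (on this read-out lower numbers stand for stronger inhibition and higher numbers for weaker inhibition), compound 1 gives > 48000 nM, which is a limit of the assay and not a number. Compound 3 `CCCc1ncn2c(O)nncc12` carries a propyl chain where compound 1 carries methyl; in this assay compound 3 gives > 48000 nM, again only a limit. Compound 2 `CCc1ncn2c(S)nncc12` holds an ethyl chain and sulfanyl; in this assay compound 2 gives > 48000 nM, also a limit. The step that the two limits leave unreadable from compound 1 to compound 3 therefore cannot be sized. Within the data shown here, compound 3 thus stands at the limit, where all values of the series so far sit (the limit of > 48000 nM in this assay, at which 3 of the 3 values shown sit).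

Compound 4 `CCCc1ncn2c(S)nncc12` differs from compound 3 in one place: sulfanyl in place of hydroxy on an aromatic carbon. Among the measured compounds shown here, no measured step isolates this exchange. For the measured compounds named here, the only sulfanyl compound so far is compound 2, and its value shows only a limit, so the pair of compound 2 and compound 3 reads nothing about the exchange. The step that the limit leaves unreadable from compound 3 to compound 4 is expected to stay unreadable, with the result again at the limit rather than a step beyond the scatter. Compound 4 is therefore estimated at 70000 nM, with a range from 20000 nM to 300000 nM.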

Compound 4, half-maximal inhibitory concentration: > 48000 nM
Compound 4: no number, only a limit; the forecaster's own chance of this, stated with the estimate: 85%; the middle value lies beyond the limit too.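

In this assay compound 4 gives > 48000 nM which is a limit of the assay and not a number. The steps to compound 4 from compound 3 and from compound 2 therefore cannot be read. The compounds shown leave open whether sulfanyl in place of hydroxy, or any change among the methyl, ethyl and propyl chains, alters inhibition at all.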